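Aryl hydrazone ureas: cytotoxicity notes on one replacement

The compounds below may be only part of what the source reports. "The series", "measured", "known", "first", "only" and "open" are said of these compounds alone.

Compound 1 `CN(C)CCn1cnnc1-c1cc(Oc2ccc(NC(=O)N/N=C/c3cc(C(C)(C)C)cc(C(C)(C)C)c3O)cc2F)ccn1` and compound 2 `COc1ccc(OC)c(/C=N/NC(=O)Nc2ccc(Oc3ccnc(-c4nncn4CCN(C)C)c3)c(F)c2)c1` share a core and differ in the aryl group on the carbon with a double bond to nitrogen. In a functional assay on U-87MG ATCC cells (Homo sapiens) for cytotoxicity, read by MTT assay, with a stated time of 72 h (on this read-out higher numbers stand for weaker inhibition and lower numbers for stronger inhibition), compound 1 gives 520 nM, and compound 2 gives 6400 nM; compound 2 thus stands at the highest of the two numbers, and its gap to compound 1 lies beyond the scatter. Going by the values given here, no step between measured compounds that differ in one place is available, so a move away from compound 2 has no anchor in the data. Compound 3 `CN(C)CCn1cnnc1-c1cc(Oc2ccc(NC(=O)N/N=C/c3ccc(F)cc3)cc2F)ccn1` is the untested member; relative to compound 2 the change is 4-fluorophenyl in place of 2,5-dimethoxyphenyl on a carbon with a double bond to nitrogen. Among the compounds with values here, with two measured points and no shared step, the expectation for compound 3 is a modest move toward lower numbers, a 1.6-fold lower number from compound 2 to compound 3 (0.20 log units; within the scatter), held loosely. Compound 3 is estimated at 4000 nM in this assay, between 1500 nM and 12000 nM.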

Compound 3, half-maximal inhibitory concentration: 2310 nM
Beside the measured number, compound 3's estimate is 1.7-fold (0.24 log units) above it; low and high end bracket the measured number.
By their numbers in this assay, from the lowest: compound 1; then compound 3; then compound 2.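

In this assay, the aryl group on the carbon with a double bond to nitrogen now has its first one-place step: 4-fluorophenyl in place of 2,5-dimethoxyphenyl gives a 2.8-fold lower number from compound 2 to compound 3 (0.44 log units; beyond the scatter). The read-out thus responds to this replacement, and the entering group carries fewer heavy atoms and no hydrogen-bond acceptors, while compound 1 remains the lowest of the three at 520 nM. No measured evidence is available to account for this step.

Still open, on these data alone, is whether the step tracks the loss of the two methoxy groups or the entry of the fluorine, a question that unsubstituted phenyl at this position would help to separate. Also open, as far as these compounds go, is how an aryl group carrying an amine or a carboxylic acid would read in this assay.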